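From 2-methoxyethyl to isobutyl on the ring amine

The source may report more compounds than this note shows. Statements on the series, on what has been measured and on what is new or still open speak of the compounds shown alone.

Compound 1, `COCCNc1nnc(SCC(=O)N(Cc2cccc([N+](=O)[O-])c2)c2ccc(F)cc2)s1`: 20.1%
Compound 2, `CCNc1nnc(SCC(=O)N(Cc2cccc([N+](=O)[O-])c2)c2ccc(F)cc2)s1`: 14.2%

In an assay on isolated protein for inhibition of Amine oxidase [flavin-containing] A (Homo sapiens), read by fluorescence and Amplex Red, with a stated time of 30 min, tested at 0.1 nM (on this read-out lower numbers stand for a weaker effect and higher numbers for a stronger effect at the one concentration tested), compound 1 gives 20.1%, the highest of the two numbers shown, and compound 2 gives 14.2%. Among the measured compounds shown here, the single measured step, a number 5.9 percentage points lower from compound 1 to compound 2 (within the scatter), stays within the scatter. Compound 3, `CC(C)CNc1nnc(SCC(=O)N(Cc2cccc([N+](=O)[O-])c2)c2ccc(F)cc2)s1`, differs from compound 1 by isopropyl in place of methoxymethyl on a saturated chain carbon bound to a nitrogen on an aromatic ring. For the measured compounds named here, only that one step bears on this change: it also removes the methoxy group, and it moved the number by nothing beyond the scatter. Compound 3 is therefore expected to give 17%, within 5% to 30%. The expected step is a number 3.1 percentage points lower from compound 1 to compound 3 (within the scatter), none beyond the scatter.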

Compound 3, a percentage reported as inhibition, at one concentration (the size of the read-out at that concentration, not a potency): 12.6%
Beside the measured number, compound 3's estimate is 4.4 percentage points above it; measured number inside the range.
By their numbers in this assay, from the lowest: compounds 3, 2 and 1 (each within the scatter of the next).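

At this position on the chain, exchanging 2-methoxyethyl for isobutyl gives a number 7.5 percentage points lower from compound 1 to compound 3 (within the scatter) in this assay and extending the chain of compound 2 to the isobutyl of compound 3 gives a number 1.6 percentage points lower from compound 2 to compound 3 (within the scatter) so neither step separates the three compounds. With the oxygen gone, the added branch and carbons leave the numbers within the scatter of each other. No measurement shown accounts for these numbers. From the compounds shown here alone, whether a terminal amine, a carboxylic acid or a much longer chain here would move the number beyond the scatter remains open.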